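The source may report more compounds than this note shows. Statements on the series, on what has been measured and on what is new or still open speak of the compounds shown alone.

Measured compounds:
- compound 1, `CN(C)C(=O)c1cccnc1NCCCN1CCN(c2ccccc2OCC2CC2)CC1`, 10 nM
- compound 2, `CN(C)C(=O)c1cccnc1NCCCN1CCN(c2ccccc2-c2ccccc2)CC1`, 63.1 nM
- compound 3, `CSc1ccccc1N1CCN(CCCNc2ncccc2C(=O)N(C)C)CC1`, 31.6 nM

In a functional assay on aorta for antagonist activity at Alpha-1D adrenergic receptor (Rattus norvegicus) (a higher number here means weaker binding, a lower number tighter binding), compound 3 stands second highest of the three numbers; its nearest neighbour is compound 2, with a 2.0-fold lower number from compound 2 to compound 3 (0.30 log units; within the scatter), and its furthest is compound 1, with a 3.2-fold higher number from compound 1 to compound 3 (0.50 log units; beyond the scatter). Compound 4, `CN(C)C(=O)c1cccnc1NCCCN1CCN(c2ccccc2C2CC2)CC1`, differs from compound 3 by cyclopropyl in place of methylsulfanyl on an aromatic carbon. Among the measured compounds shown here, no measured step covers this exact exchange; the steps that bear on it only show that the three groups tried at this position span a modest range, a 6.3-fold higher number from compound 1 to compound 2 (0.80 log units; beyond the scatter) being the widest. The exchange is therefore expected to give a step of a 1.1-fold lower number from compound 3 to compound 4 (0.02 log units; within the scatter), that is, none beyond the scatter. Compound 4 is estimated at 30 nM, with a range from 10 nM to 100 nM.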

Compound 4, dissociation constant: 63.1 nM
The estimate for compound 4 lay 2.1-fold (0.32 log units) below the measured number; measured number inside the range.
By their numbers in this assay, from the lowest: compound 1; then compounds 3, 2 and 4 (each within the scatter of the next).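

In this assay, cyclopropyl on the aromatic carbon falls in with methylsulfanyl (a 2.0-fold higher number from compound 3 to compound 4 (0.30 log units; within the scatter)) and phenyl (no change at the digits printed from compound 2 to compound 4 (within the scatter)), while cyclopropylmethoxy stands apart from it (a 6.3-fold higher number from compound 1 to compound 4 (0.80 log units; beyond the scatter)). Compound 1 thus remains the tightest of the four, and the three-membered ring that compound 1 and compound 4 share does not by itself give the number of compound 1. Nothing available accounts for these steps. On these data alone, it remains open whether a smaller or longer alkoxy chain, such as methoxy or butoxy, would stand with compound 1. The compounds shown also leave open how an amine or a carboxylic acid would fare at this place.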